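Swapping the Terminal Amine on a Pentyl Chain

A few compounds are considered here, and "the series" means these few. Any claim that something is new, unique, unknown or untested is made for them only; others in the source may bear on it.

Within the data shown here, compound 2 `CN1CCN(CCCCCn2c3c(c4ccccc42)C(=O)c2c[n+]([O-])c4ccccc4c2C3=O)CC1` gives the higher of the two numbers so far in a functional assay on A-375 cells (Homo sapiens) for cytotoxicity, read by MTT assay, with a stated time of 72 h (a higher number here means a weaker inhibitor, a lower number a stronger inhibitor), at 1710 nM, meaning it is the weaker of the two measured compounds. Among the measured compounds shown here, its only neighbour, compound 1 `CN1CCN(CCCCCCn2c3c(c4ccccc42)C(=O)c2c[n+]([O-])c4ccccc4c2C3=O)CC1`, gives 630 nM; the single measured step, a 2.7-fold higher number from compound 1 to compound 2 (0.43 log units; beyond the scatter), came from lengthening or shortening the saturated chain, not from changing the amine at its end.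

Compound 3 `CN(C)CCCCCn1c2c(c3ccccc31)C(=O)c1c[n+]([O-])c3ccccc3c1C2=O` differs from compound 2 in a different way: dimethylamino in place of 4-methylpiperazin-1-yl on a saturated chain carbon, five bonds along the chain from an aromatic nitrogen. For the measured compounds named here, no measured pair shows this change, so the one known step offers only indirect guidance, a reminder that small edits to this chain end can shift this assay modestly. Since the chain length is kept and only the end group is traded, the expected step of a 1.1-fold lower number from compound 2 to compound 3 (0.06 log units; within the scatter) is small, with no firm basis for a direction. Compound 3 is therefore expected to give about 1500 nM in this assay, within a range from 500 nM to 4500 nM.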

Compound 3, half-maximal inhibitory concentration: 560 nM
Beside the measured number, compound 3's estimate is 2.7-fold (0.43 log units) above it; low and high end bracket the measured number.
By their numbers in this assay, from the lowest: compounds 3 and 1 (each within the scatter of the next); then compound 2.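

Trading the end group alone, with dimethylamino in place of 4-methylpiperazin-1-yl on a saturated chain carbon, five bonds along the chain from an aromatic nitrogen, gives a 3.1-fold lower number from compound 2 to compound 3 (0.48 log units; beyond the scatter) in this assay, so this chain end matters in its own right and chain length is not the only edit that moves the number here. The group that enters has 3 heavy atoms and no ring, while the one that leaves has 7 heavy atoms and a six-membered ring, so the ring is not needed at this place for a number like that of compound 1: the comparison reads a 1.1-fold lower number from compound 1 to compound 3 (0.05 log units; within the scatter), and dimethylamino and (4-methylpiperazin-1-yl)methyl at this place cannot be told apart in this assay. Nothing on hand explains why the end group shifts the number.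

Whether dimethylamino keeps the same standing on a longer chain remains open, since the compounds shown pair it with one chain length only. Also open, on these data alone, is what other end groups, such as diethylamino, a morpholine ring or a primary amine, would give at this place.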